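Chloro Substitution on the Thiadiazole Chromone Thioether

A few compounds are considered here, and "the series" means these few. Any claim that something is new, unique, unknown or untested is made for them only; others in the source may bear on it.

Among the measured compounds shown here, in this series the two compounds with numbers so far are compound 1 `Cc1nnc(SCc2coc3ccc(Cl)cc3c2=O)o1` and compound 2 `Cc1nnc(SCc2coc3ccccc3c2=O)s1`. In a functional assay on HEp-2 cells (Homo sapiens) for cytotoxicity, read by MTT assay, with a stated time of 72 h (a higher number here means a weaker inhibitor, a lower number a stronger inhibitor), compound 1 gives 6400 nM, while compound 2 gives 2900 nM. Compound 2 thus stands at the lower of the two numbers, and compound 1 lies higher by a gap that goes beyond the usual scatter. The two differ in more than one place, so their numbers are taken only as they stand and no single cause is read into them.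

Compound 3 `Cc1nnc(SCc2coc3ccc(Cl)cc3c2=O)s1` departs from compound 2 in one place: chloro in place of hydrogen on an aromatic carbon. The place is an aromatic carbon of the six-membered carbon ring of the fused system, meta to a fused ring and para to a fused ring. For the measured compounds named here, no measured pair shows this change on its own. The author expects the step in this assay to be small, leaning toward a weaker inhibitor, and likely within or only just beyond the scatter; the expected step is a 1.4-fold higher number from compound 2 to compound 3 (0.14 log units; within the scatter). For compound 3 the estimate is 4000 nM, with a range from 1500 nM to 11000 nM.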

Compound 3, half-maximal inhibitory concentration: 4200 nM
The estimate for compound 3 lay 1.1-fold (0.02 log units) below the measured number; the measured number falls inside the stated range.
By their numbers in this assay, from the lowest: compounds 2, 3 and 1 (each within the scatter of the next, the first and the last beyond it).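

Among the compounds shown here, this is the first pair in which chloro in place of hydrogen on an aromatic carbon, meta to a fused ring and para to a fused ring, can be read on its own: in this assay it gives a 1.4-fold higher number from compound 2 to compound 3 (0.16 log units; within the scatter) and so lies within the scatter, which means that compound 2 and compound 3 cannot be told apart at this position. The new compound also isolates a second change, since 5-methyl-1,3,4-thiadiazol-2-yl in place of 5-methyl-1,3,4-oxadiazol-2-yl on a sulfur, with the chloro kept, gives a 1.5-fold lower number from compound 1 to compound 3 (0.18 log units; within the scatter) and again stays within the scatter, so neither single change shown here moves the number beyond it. No measurement in this account offers an explanation for either step.

The compounds shown leave open whether another group at this same place, such as fluoro, methoxy or an amine, would give a step beyond the scatter. They also leave open whether a longer chain in place of the methyl on the 5-methyl-1,3,4-thiadiazol-2-yl group would change the number in this assay at all.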